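This account rests on a few compounds, and the source may have more. Where it says the series, first, only, none or still open, it means among the compounds named here.

Compound 1, `Cc1cc(-c2ccccc2)nnc1NCCN`, was tested in a functional assay on the whole organism for positive allosteric modulation, with Mus musculus as the target; a higher number here means that more compound is needed for the effect, a lower number that less compound is needed. In this assay compound 1 reached only the limit of > 30 mg/kg, so its position is known as a bound rather than a number. Compound 2, `Cc1cc(-c2ccccc2)nnc1NCCCN`, also gave only a limit in this assay, > 30 mg/kg. Among the compounds with values here, the step that the two limits leave unreadable from compound 1 to compound 2 cannot be read, and the only evidence is the limit of > 30 mg/kg in this assay, at which 2 of the 2 values shown sit. Compound 3, `Cc1cc(-c2ccccc2)nnc1NCCN(C)C`, differs from compound 1 by dimethylamino in place of amino on a saturated chain carbon, two bonds along the chain from a nitrogen on an aromatic ring. With no readable step to build on, the expected step that the limit leaves unreadable from compound 1 to compound 3 is centred on no change. Compound 3 is therefore estimated at 40 mg/kg, between 12 mg/kg and 130 mg/kg, most likely again a limit.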

Compound 3, dose for half-maximal effect: > 30 mg/kg
Compound 3 ended at the assay's limit; the forecaster's own chance of this, stated with the estimate: 75%; the middle value is on the limit's open side.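

Compound 1, compound 2 and compound 3 each give only a limit in this assay, so no step among them can be read: the limit of > 30 mg/kg in this assay, at which 3 of the 3 values shown sit.

The compounds shown leave open whether amino, aminomethyl and dimethylamino differ at all in this assay.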